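The source may hold more compounds than are shown below. What is called first, only, known or untested is meant among the compounds shown, and "the series" means these compounds.

In a functional assay on SMMC-7721 cells (Homo sapiens) for cytotoxicity, read by MTT assay, with a stated time of 24 h (a lower number here means a stronger inhibitor, a higher number a weaker inhibitor), compound 1 (`O=C1/C(=C/c2cccnc2)CNC/C1=C\c1ccccc1C(F)(F)F`) gives 5100 nM and compound 2 (`Cc1ccc(S(=O)(=O)N2C/C(=C\c3cccnc3)C(=O)/C(=C/c3ccccc3C(F)(F)F)C2)cc1`) gives 6700 nM while compound 3 (`O=C1/C(=C/c2cccnc2)CN(S(=O)(=O)c2ccc(C(F)(F)F)cc2)C/C1=C\c1ccccc1C(F)(F)F`) gives 1730 nM as the lowest of the three numbers. Compound 4 (`O=C1/C(=C/c2cccnc2)CN(S(=O)(=O)c2ccc(Cl)cc2)C/C1=C\c1ccccc1C(F)(F)F`) is not yet measured. It differs from compound 3 by chloro in place of trifluoromethyl on an aromatic carbon with chloro in place of trifluoromethyl on an aromatic carbon, para to a large group. For the measured compounds named here, two measured steps bear on this change. The step that puts (4-methylphenyl)sulfonyl in place of hydrogen on the amine nitrogen (a 1.3-fold higher number from compound 1 to compound 2 (0.12 log units; within the scatter)) is a distant guide, as it lies elsewhere in the structure. The closer guide is trifluoromethyl in place of methyl on an aromatic carbon (a 3.9-fold lower number from compound 2 to compound 3 (0.59 log units; beyond the scatter)) which is a modest step at the same place. Going by the values given here, no chloro compound has been measured yet, so only a small move to a higher number is expected, probably within the scatter. The expected step is a 1.4-fold higher number from compound 3 to compound 4 (0.16 log units; within the scatter) in this assay on this reading. The estimate for compound 4 is 2500 nM (1200 nM to 5500 nM).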

Compound 4, half-maximal inhibitory concentration: 4880 nM
Compound 4: the middle estimate sits 2.0-fold (0.29 log units) below what was measured; measured number inside the range.
By their numbers in this assay, from the lowest: compound 3; then compounds 4, 1 and 2 (each within the scatter of the next).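

In this assay the change from 4-(trifluoromethyl)phenyl to 4-chlorophenyl gives a 2.8-fold higher number from compound 3 to compound 4 (0.45 log units; beyond the scatter) and shows that the lower number at this place does not carry over from trifluoromethyl to chloro. Chloro in place of methyl gives a 1.4-fold lower number from compound 2 to compound 4 (0.14 log units; within the scatter) and does not separate these two groups. The (4-chlorophenyl)sulfonyl group in place of hydrogen on the amine nitrogen gives a 1.0-fold lower number from compound 1 to compound 4 (0.02 log units; within the scatter) and so leaves the number of the core of compound 1 unmoved, whereas among methyl, chloro and trifluoromethyl at this place only trifluoromethyl stands apart.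

As far as these compounds go, whether a nitrile, a methoxy group or an amine at this place would stand with trifluoromethyl or with chloro remains open. Nothing available accounts for the gap between trifluoromethyl and chloro.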